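Solubility of Two Macrolide Analogues and a Quinoline Variant

The source may report more compounds than this note shows. Statements on the series, on what has been measured and on what is new or still open speak of the compounds shown alone.

Compound 1 `CC[C@H]1OC(=O)[C@H](C)[C@@H](O)[C@H](C)[C@@H](O[C@@H]2O[C@H](C)C[C@H](N(C)C)[C@H]2OCCCNC(=O)CCCNc2ccnc3cc(Cl)ccc23)[C@](C)(O)C[C@@H](C)CN(C)[C@H](C)[C@@H](O)[C@]1(C)O` and compound 2 `CC[C@H]1OC(=O)[C@H](C)[C@@H](O[C@H]2C[C@@](C)(OC)[C@@H](O)[C@H](C)O2)[C@H](C)[C@@H](O[C@@H]2O[C@H](C)C[C@H](N(C)C)[C@H]2OCCCNc2ccnc3ccccc23)[C@](C)(O)C[C@@H](C)CN(C)[C@H](C)[C@@H](O)[C@]1(C)O` share a macrolide core with a substituted amine side chain. In a physicochemical assay for solubility, at pH 4 (on this read-out higher numbers stand for higher solubility and lower numbers for lower solubility), compound 1 reaches only the limit of the assay, > 10000 ug/mL. In this assay compound 2 likewise gives a limit, > 10000 ug/mL, so its standing is known only as the limit of > 10000 ug/mL in this assay, at which 2 of the 2 values shown sit. Compound 3 `CC[C@H]1OC(=O)[C@H](C)[C@@H](O[C@H]2C[C@@](C)(OC)[C@@H](O)[C@H](C)O2)[C@H](C)[C@@H](O[C@@H]2O[C@H](C)C[C@H](N(C)C)[C@H]2OCCCNCc2cnc3ccccc3c2)[C@](C)(O)C[C@@H](C)CN(C)[C@H](C)[C@@H](O)[C@]1(C)O` carries (quinolin-3-yl)methyl in place of quinolin-4-yl on an amine nitrogen. For the measured compounds named here, no measured step constrains this change, and compound 3 is expected to stay near the limit, with a number no higher from compound 2 to compound 3 (the limit leaves the size open) amounting to no change beyond the scatter. The estimate for compound 3 is 10000 ug/mL, between 3000 ug/mL and 10000 ug/mL.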

Compound 3, solubility: > 10000 ug/mL
Compound 3 ended at the assay's limit (the forecaster's own chance of this, stated with the estimate: 75%); the middle value sits exactly at the limit.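

Compound 2 and compound 3 both stand at the limit of this assay, so no step can be read between them: the limit of > 10000 ug/mL in this assay, at which 3 of the 3 values shown sit.

The compounds shown leave open whether replacing quinolin-4-yl with (quinolin-3-yl)methyl changes solubility at all, and by how much.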